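The source may hold more compounds than are shown below. What is called first, only, known or untested is meant among the compounds shown, and "the series" means these compounds.

Compound 1 `CCCCCN(CCCCC)C(=O)N1CCN(C(=O)N(c2ccccc2)c2ccccc2)[C@H](C(=O)NCCNC(C)=O)C1` — in an assay on CHO cells for binding affinity to Substance-P receptor (Homo sapiens) (on this read-out lower numbers stand for stronger inhibition and higher numbers for weaker inhibition), compound 1 gives 140 nM.
Compound 2 `CCCCCN(CCCCC)C(=O)N1CCN(C(=O)N(c2ccccc2)c2ccccc2)[C@H](C(=O)NCCN(CC)CC)C1` — compound 2 gives 11 nM.
Compound 3 `CCCCCN(CCCCC)C(=O)N1CCN(C(=O)N(c2ccccc2)c2ccccc2)[C@H](C(=O)N(C)CCN(C)Cc2ccccc2OC)C1` — compound 3 gives 17 nM.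

Among these three numbers compound 3 sits within the scatter of compound 2, and beyond the scatter below compound 1. Compound 4 `CCCCCN(CCCCC)C(=O)N1CCN(C(=O)N(c2ccccc2)c2ccccc2)[C@H](C(=O)NCCN(C)Cc2ccccc2OC)C1` differs from compound 3 by hydrogen in place of methyl on an amide-type nitrogen. For the measured compounds named here, the one measured step, a 13-fold lower number from compound 1 to compound 2 (1.10 log units; beyond the scatter), concerns a different change at a different place and so does not bear on this one; no pair among the measured compounds tests hydrogen against methyl on an amide-type nitrogen. The expected step for compound 4 is therefore a 1.1-fold lower number from compound 3 to compound 4 (0.05 log units; within the scatter), none beyond the scatter. Compound 4 is estimated at 15 nM, within a range from 5 nM to 45 nM.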

Compound 4, half-maximal inhibitory concentration: 9 nM
Estimate against measurement, compound 4: 1.7-fold (0.22 log units) above, and the stated range covers the measured number.
By their numbers in this assay, from the lowest: compounds 4, 2 and 3 (each within the scatter of the next); then compound 1.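

In this assay, hydrogen in place of methyl on the amide-type nitrogen gives a 1.9-fold lower number from compound 3 to compound 4 (0.28 log units; within the scatter) and stays within the scatter, so at this position the two groups are not told apart. With hydrogen on that nitrogen, (2-methoxybenzyl)(methyl)amino gives a 1.2-fold lower number from compound 2 to compound 4 (0.09 log units; within the scatter) against diethylamino, again within the scatter. Against acetamido it gives a 16-fold lower number from compound 1 to compound 4 (1.19 log units; beyond the scatter) and lies beyond the scatter. The compounds shown leave open how an ethyl or benzyl group on the amide-type nitrogen would read, and how a carboxylic acid on the chain would compare. Nothing measured here accounts for these steps.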